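A few compounds are considered here, and "the series" means these few. Any claim that something is new, unique, unknown or untested is made for them only; others in the source may bear on it.

Compound 1, `CS(=O)(=O)NCCCCCCN(c1nc(C(=O)NCc2ccc(F)cc2)c(O)c2ncccc12)S(C)(=O)=O`, gives 4000 nM in a functional assay on HCT-116 cells (Homo sapiens) for cytotoxicity, read by MTT assay, with a stated time of 72 h; on this read-out lower numbers stand for stronger inhibition and higher numbers for weaker inhibition.
Compound 2, `CNCCCNc1c(C(=O)NCc2ccc(F)cc2)nc(Br)c2cccnc12`, gives > 10000 nM in this assay.

Of the two results, only compound 1 is a true number. For compound 2 the read-out is a limit of this assay, not a number, so its cytotoxicity is known only as weaker than that limit. Compound 2 sits at the limit of > 10000 nM in this assay, at which 1 of the 2 values shown sits, the weaker end of what has been measured here.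

Compound 3, `O=C(NCc1ccc(F)cc1)c1nc(Br)c2cccnc2c1NCCO`, keeps the core of compound 2 and differs from it in one place: hydroxy in place of (methylamino)methyl on a saturated chain carbon, two bonds along the chain from a nitrogen on an aromatic ring

No measured pair among the compounds shown differs in this one place, so the size and direction of such a step cannot be read from the data. As compound 2 itself gives only a limit, the expected step that the limit leaves unreadable from compound 2 to compound 3 is taken as no change beyond the scatter, and compound 3 is expected to stay in the weak region.

Compound 3 is therefore estimated at 15000 nM in this assay, within a range from 4000 nM to 60000 nM, with a real chance that the assay again reports only a limit.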

Compound 3, half-maximal inhibitory concentration: > 20000 nM
Compound 3 ended at the assay's limit; the forecaster's own chance of this, stated with the estimate: 70%; middle value at least 1.3-fold (0.12 log units) from the limit.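

Compound 2 and compound 3 each give only a limit in this assay, not a true number, and the step between them cannot be read. The compounds shown leave open how large that change from (methylamino)methyl to hydroxy is, and in which direction it moves cytotoxicity in these cells.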